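The source may report more compounds than this note shows. Statements on the series, on what has been measured and on what is new or still open speak of the compounds shown alone.

Compound 3 `O=C(NCCCNc1ccnc(Nc2cccc(NC(=O)N3CCCC3)c2)n1)C1CCC1` is measured in an assay on HEK293 cells for displacement of a labelled ligand from MAP/microtubule affinity-regulating kinase 4 (Homo sapiens), read by NanoBRET (a lower number here means a stronger inhibitor, a higher number a weaker inhibitor), only as a limit, > 10000 nM. Compound 1 `NS(=O)(=O)c1ccc(CNc2nc(Nc3cccc(NC(=O)N4CCCC4)c3)ncc2Br)cc1` likewise reaches only a limit in this assay, > 10000 nM. Compound 2 `NS(=O)(=O)c1ccc(CNc2ccnc(Nc3cccc(NC(=O)N4CCCC4)c3)n2)cc1` also gives only a limit there, > 10000 nM. All three values share (the limit of > 10000 nM in this assay, at which 3 of the 3 values shown sit), so the step that the two limits leave unreadable from compound 1 to compound 2 and the step that the two limits leave unreadable from compound 2 to compound 3 cannot be read. Compound 4 `O=C(NCCCNc1nc(Nc2cccc(NC(=O)N3CCCC3)c2)ncc1Br)C1CCC1` differs from compound 3 by bromo in place of hydrogen on an aromatic carbon. Among the compounds with values here, the one measured step on this same change, a step that the two limits leave unreadable from compound 1 to compound 2, runs in the reverse direction and yields no size, so no direction can be drawn from it. Compound 4 is therefore expected to remain near the limit, the step that the limit leaves unreadable from compound 3 to compound 4 meaning no change beyond the scatter. The estimate for compound 4 in this assay is 15000 nM, spanning 4000 nM to 60000 nM.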

Compound 4, half-maximal inhibitory concentration: 72 nM
For compound 4 the middle estimate is 210-fold (2.32 log units) above the measured one; the whole stated range lies above it.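

Bromo in place of hydrogen gives an at least 130-fold lower number from compound 3 to compound 4 (2.14 log units; beyond the scatter) in this assay as the first readable step in the series. Compound 1 carries the same bromo, yet its > 10000 nM is only a limit, so bromo alone does not suffice in these compounds. With bromo kept, the side-chain change gives an at least 130-fold lower number from compound 1 to compound 4 (2.14 log units; beyond the scatter) and so the chain also counts at this position.

From the compounds shown here alone, whether chloro or methyl on this aromatic carbon, or a longer chain, would hold this level stays open. The remaining steps cannot be read because those compounds share one limit: the limit of > 10000 nM in this assay, at which 3 of the 4 values shown sit.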